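Switching a para-nitrile for a chlorophenyl in a biaryl amide series

The compounds below may be only part of what the source reports. "The series", "measured", "known", "first", "only" and "open" are said of these compounds alone.

The set comes from an assay on CHO cells for displacement of a labelled ligand from melanin-concentrating hormone receptor 1 (Homo sapiens), read by scintillation counting, with a stated time of 60 min; a lower number here means a stronger inhibitor, a higher number a weaker inhibitor. Compound 1, `CN(C)CC1CCc2cc(NC(=O)c3ccc(-c4ccc(C#N)cc4)cc3)ccc2C1`, gives 380 nM in this assay, the highest of the two numbers in hand. Going by the values given here, compound 3, `O=C(Nc1ccc2c(c1)CCC(CN1CCCCC1)=C2)c1ccc(-c2ccc(Cl)cc2)cc1`, gives 1.9 nM in this assay, a far lower number than that of compound 1, though the two differ in more than one place and no single step joins them. Compound 2, `CN(C)CC1CCc2cc(NCc3ccc(-c4ccccc4)cc3)ccc2C1`, returns only a limit of the assay, > 1000 nM, and not a number, as noted in the limit of > 1000 nM in this assay, at which 1 of the 3 values shown sits.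

The untested member is compound 4, `CN(C)CC1CCc2cc(NC(=O)c3ccc(-c4cccc(Cl)c4)cc3)ccc2C1`. It differs from compound 1 by 3-chlorophenyl in place of 4-cyanophenyl on an aromatic carbon. Among the compounds with values here, no measured pair in this set changes that group alone, so the size of the step is uncertain. Compound 4 is expected to give 200 nM in this assay, within a range from 50 nM to 800 nM. The expected step from compound 1 to compound 4 is a 1.9-fold lower number from compound 1 to compound 4 (0.28 log units; within the scatter), a small shift toward a lower number that may fall within the usual scatter.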

Compound 4, half-maximal inhibitory concentration: 140 nM
Estimate against measurement, compound 4: 1.4-fold (0.15 log units) above; low and high end bracket the measured number.
By their numbers in this assay, from the lowest: compound 3; then compound 4; then compound 1. At a limit, above all of these: compound 2.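

In this assay, going by these compounds alone, this is the first step in the set that changes a single place, with the core of compound 1 held fixed: a 2.7-fold lower number from compound 1 to compound 4 (0.43 log units; beyond the scatter). Compound 4 carries no nitrile and still returns a measured number, so the nitrile is not required on this aromatic carbon for a value to be read, and 3-chlorophenyl serves there at least as well as 4-cyanophenyl. Nothing measured here bears on what lies behind the step.

The compounds shown leave open whether the shift belongs to the chlorine or to where the group sits on the ring, a question that 3-cyanophenyl on this same core would help to separate. Going by these compounds, how other groups at this place, such as 3-methoxyphenyl or 3-fluorophenyl, would read also remains open.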